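Changing the aryl group on a growth-inhibiting series

The source may hold more compounds than are shown below. What is called first, only, known or untested is meant among the compounds shown, and "the series" means these compounds.

Measured in a functional assay on K562 cells (Homo sapiens) for inhibition, read by fluorescence, with a stated time of 72 h; on this read-out lower numbers stand for stronger inhibition of growth and higher numbers for weaker inhibition of growth:
Compound 1 `CC(C)CCn1cnc2c(Nc3ccc(Cl)cc3)nc(N[C@H]3CC[C@H](N)CC3)nc21` gives 1800 nM
Compound 2 `N[C@H]1CC[C@H](Nc2nc(Nc3ccc(Cl)cc3)c3ncn(C4CCCCC4)c3n2)CC1` gives 1700 nM
Compound 3 `CCCCn1cnc2c(Nc3cc(OC)cc(OC)c3)nc(N[C@H]3CC[C@H](N)CC3)nc21` gives 2400 nM

The value of compound 3 lies within the usual scatter of the other two, so these three numbers cannot be put in a reliable order. The unmeasured compound 4 `CCCCn1cnc2c(Nc3ccc(Cl)cc3)nc(N[C@H]3CC[C@H](N)CC3)nc21` differs from compound 3 in one place: 4-chlorophenyl in place of 3,5-dimethoxyphenyl on a nitrogen on an aromatic ring. Going by the values given here, no measured pair makes this exact change, so the evidence is indirect. The 4-chlorophenyl group is already present in compound 1 at 1800 nM and in compound 2 at 1700 nM. Among the compounds with values here, the only measured step is a 1.1-fold lower number from compound 1 to compound 2 (0.02 log units; within the scatter), and it leaves the 4-chlorophenyl untouched. Only compound 3 carries 3,5-dimethoxyphenyl, which makes this thin support, but its value sits within the scatter of both. No step beyond the scatter is therefore expected in this assay. The expected change is a 1.3-fold lower number from compound 3 to compound 4 (0.12 log units; within the scatter). For compound 4 the estimated value is 1800 nM, with an expected range from 900 nM to 3600 nM.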

Compound 4, concentration for 50% growth inhibition: 2700 nM
The estimate for compound 4 lay 1.5-fold (0.18 log units) below the measured number; the measured number falls inside the stated range.
By their numbers in this assay, from the lowest: compounds 2, 1, 3 and 4 (each within the scatter of the next).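

In this assay, going by these compounds alone, the first direct comparison at this position gives a 1.1-fold higher number from compound 3 to compound 4 (0.05 log units; within the scatter), so 4-chlorophenyl and 3,5-dimethoxyphenyl on this nitrogen cannot be told apart, although the entering group has fewer heavy atoms and no hydrogen-bond acceptors. Changes on the aromatic nitrogen also remain unresolved: butyl in place of cyclohexyl gives a 1.6-fold higher number from compound 2 to compound 4 (0.20 log units; within the scatter), and removing one methyl from the isopentyl chain gives a 1.5-fold higher number from compound 1 to compound 4 (0.18 log units; within the scatter). No supporting measurement is available to interpret these results.

Going by these compounds, whether a pyridyl or carboxyphenyl group on this nitrogen, or a longer chain on the aromatic nitrogen, would give a difference beyond the scatter remains open. With every step shown here within the scatter, these compounds do not identify any group at either position that matters for growth inhibition.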